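Aryl Swap on the Ring Nitrogen: Expected Cytotoxicity of Compound 3

The source may report more compounds than this note shows. Statements on the series, on what has been measured and on what is new or still open speak of the compounds shown alone.

Compound 2 `Oc1cc(C(F)(F)F)ccc1-c1nc(-c2ccccc2O)n(-c2ccc(OC(F)(F)F)cc2)n1` was tested in a functional assay on PC-12 cells (Rattus norvegicus) for cytotoxicity, read by MTT assay, with stated times of 2 h and 24 h, tested at 1 uM (on this read-out higher numbers stand for a stronger effect at the one concentration tested and lower numbers for a weaker effect), where compound 2 gives 65.5%. For the measured compounds named here, this is the lower of the two numbers measured so far, but the only other measured compound, compound 1 `Cc1ccc(-n2nc(-c3ccc(C(F)(F)F)cc3O)nc2-c2ccccc2O)cc1`, gives 71.5% in this assay, and the step of a number 6 percentage points lower from compound 1 to compound 2 (within the scatter) lies within the scatter, so the two compounds cannot be ordered. Compound 3 `Oc1cc(C(F)(F)F)ccc1-c1nc(-c2ccccc2O)n(-c2ccccc2C(F)(F)F)n1` has not yet been measured. It differs from compound 2 in one place: 2-(trifluoromethyl)phenyl in place of 4-(trifluoromethoxy)phenyl on an aromatic nitrogen. Going by the values given here, the only measured step, trifluoromethoxy in place of methyl on an aromatic carbon, changed the read-out by an amount within the scatter; no measured step speaks to a 2-(trifluoromethyl)phenyl group on the aromatic nitrogen. Among the compounds with values here, with only that comparison to lean on, compound 3 is expected to give 64% in this assay, within a range from 46% to 82%. The expected step of a number 1.5 percentage points lower from compound 2 to compound 3 (within the scatter) is therefore estimated to stay within the scatter.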

Compound 3, a percentage reported as activity, at one concentration (the size of the read-out at that concentration, not a potency): 71%
For compound 3 the middle estimate is 7 percentage points below the measured one; the measured number falls inside the stated range.
By their numbers in this assay, from the lowest: compounds 2, 3 and 1 (each within the scatter of the next).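

In this assay, 2-(trifluoromethyl)phenyl in place of 4-(trifluoromethoxy)phenyl on the aromatic nitrogen gives a number 5.5 percentage points higher from compound 2 to compound 3 (within the scatter) and, in place of 4-methylphenyl, gives a number 0.5 percentage points lower from compound 1 to compound 3 (within the scatter) on the same read-out. For the compounds shown here, the aromatic nitrogen has now carried three different aryl groups, and this is the first time the group on it has been exchanged for one with a trifluoromethyl group, yet no step among the three compounds leaves the scatter, so the read-out does not separate them. Nothing at hand gives a reason for this result.

Going by these compounds, whether a phenyl ring bearing an amine or a carboxylic acid, or a plain ethyl chain in place of the aryl group, would move the number beyond the scatter remains open. The read-out, taken at one concentration, also leaves the potency of all three compounds unknown.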